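A Bromo to Fluoro Swap at the Assay Limit

The source may report more compounds than this note shows. Statements on the series, on what has been measured and on what is new or still open speak of the compounds shown alone.

In a functional assay on HeLa cells (Homo sapiens) for cytotoxicity, read by MTT assay, with a stated time of 48 h (a higher number here means a weaker inhibitor, a lower number a stronger inhibitor), compound 1 (`OC[C@@H]1C[C@H](CO)[C@@H]2C(c3ccc(Br)cc3)=NO[C@H]12`) gives > 50 ug/mL as a limit of the assay, not a number. Compound 2 (`COc1ccc(C2=NO[C@@H]3[C@H](CO)C[C@H](CO)[C@H]23)cc1OC`) gives > 50 ug/mL as a limit too. Compound 3 (`OC[C@@H]1C[C@H](CO)[C@@H]2C(c3ccc(F)cc3)=NO[C@H]12`) has fluoro in place of bromo on an aromatic carbon, para to a large group (fluoro in place of bromo on an aromatic carbon). Among the measured compounds shown here, no measured step shows what this change does in this assay and compound 1 offers only a limit, so no step beyond the scatter is expected in either direction. The expected step (a step that the limit leaves unreadable from compound 1 to compound 3) stays within the scatter. Compound 3 is estimated at 60 ug/mL with 30 ug/mL to 120 ug/mL as the expected range, and a report of only a limit is likely.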

Compound 3, half-maximal inhibitory concentration: > 50 ug/mL
Compound 3 ended at the assay's limit; the forecaster's own chance of this, stated with the estimate: 85%; the middle value is on the limit's open side.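

No step can be read from compound 1 to compound 3, because both stop at the same assay limit: the limit of > 50 ug/mL in this assay, at which 3 of the 3 values shown sit. The compounds shown leave open what fluoro in place of bromo does in this assay.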